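A few compounds are considered here, and "the series" means these few. Any claim that something is new, unique, unknown or untested is made for them only; others in the source may bear on it.

Compound 1 `O=C(N/N=C/c1ccccc1)Nc1ccc(Oc2ccnc3[nH]ccc23)c(F)c1` gives 2380 nM in a functional assay on MCF7 cells (Homo sapiens) for antiproliferative activity, read by MTT assay, with a stated time of 72 h; a lower number here means a stronger inhibitor, a higher number a weaker inhibitor. Compound 2 `N#Cc1ccc(/C=N/NC(=O)Nc2ccc(Oc3ccnc4[nH]ccc34)c(F)c2)cc1` gives "not active" (no number reported) in this assay, reported without a number. Compound 3 `O=C(N/N=C/c1ccc([N+](=O)[O-])cc1)Nc1ccc(Oc2ccnc3[nH]ccc23)c(F)c1` gives 4000 nM in this assay.

On these numbers, compound 3 holds the higher of the two reported values, with compound 1 nearest to it; the step of a 1.7-fold higher number from compound 1 to compound 3 (0.23 log units; within the scatter) lies within the scatter. Compound 4 `O=C(N/N=C/c1ccc(F)cc1Cl)Nc1ccc(Oc2ccnc3[nH]ccc23)c(F)c1` has not yet been measured. It differs from compound 3 in one place: 2-chloro-4-fluorophenyl in place of 4-nitrophenyl on a carbon with a double bond to nitrogen. Going by the values given here, the single measured step that bears on this position, the one from compound 1 to compound 3, is within the scatter, and no step involving a halogen at this position exists among the measured compounds. Compound 4 is therefore expected to fall near compound 3, with the step of a 1.4-fold lower number from compound 3 to compound 4 (0.15 log units; within the scatter) not expected to exceed the scatter. The estimate for compound 4 in this assay is 2800 nM, with a range from 900 nM to 9000 nM.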

Compound 4, half-maximal inhibitory concentration: 7610 nM
The estimate for compound 4 lay 2.7-fold (0.43 log units) below the measured number, and the stated range covers the measured number.
By their numbers in this assay, from the lowest: compounds 1, 3 and 4 (each within the scatter of the next, the first and the last beyond it).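

In this assay, going by these compounds alone, the change from phenyl to 2-chloro-4-fluorophenyl on a carbon with a double bond to nitrogen gives a 3.2-fold higher number from compound 1 to compound 4 (0.50 log units; beyond the scatter) and so the first step at this position beyond the scatter, though a modest one. Against 4-nitrophenyl the same group gives only a 1.9-fold higher number from compound 3 to compound 4 (0.28 log units; within the scatter) and cannot be separated from it. Nothing available accounts for either step. Going by these compounds, whether the chlorine or the fluorine alone would carry this step stays open, and so does how a ring bearing an amine or a carboxylic acid would read.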